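The source may report more compounds than this note shows. Statements on the series, on what has been measured and on what is new or still open speak of the compounds shown alone.

Measured so far:
- compound 1, `O=C1NCCN1CCCCN1CCC(c2cn(-c3ccc(F)cc3)c3ccc(Cl)cc23)CC1`: > 2.2 umol/kg
- compound 2, `O=C1NCCN1CCN1CCC(c2cn(-c3ccc(F)cc3)c3ccc(C(F)(F)F)cc23)CC1`: 0.11 umol/kg
- compound 3, `CN1CC=C(c2cn(-c3ccc(F)cc3)c3ccccc23)CC1`: 0.15 umol/kg

In a functional assay on the whole organism for inhibition, with Rattus norvegicus as the target (a higher number here means that more compound is needed for the effect, a lower number that less compound is needed), compound 2 gives 0.11 umol/kg, the lowest of the two numbers in hand. Compound 3 gives 0.15 umol/kg in this assay, and this sits within the scatter of the value of compound 2, so no order between the two is claimed. Compound 1 gives only > 2.2 umol/kg, which is a limit of the assay and not a number, as the limit of > 2.2 umol/kg in this assay, at which 1 of the 3 values shown sits, records.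

Compound 4, `O=C1NCCN1CCN1CCC(c2cn(-c3ccc(F)cc3)c3ccc(Br)cc23)CC1`, has not yet been measured. It differs from compound 2 in one place: bromo in place of trifluoromethyl on an aromatic carbon. Going by the values given here, no pair among the measured compounds isolates this change, so the size of the step rests on expectation alone. The change at that position is expected to cost little in this assay, either staying within the scatter or raising the number modestly.

Compound 4 is therefore expected to give 0.2 umol/kg in this assay, with a range from 0.07 umol/kg to 0.6 umol/kg. The step of a 1.8-fold higher number from compound 2 to compound 4 (0.26 log units; within the scatter) that this estimate means is expected to be small, if anything towards a higher number.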

Compound 4, dose for half-maximal effect: 0.032 umol/kg
Compound 4: middle estimate off by 6.3-fold (0.80 log units), on the high side; the measured number lies below the stated range.
By their numbers in this assay, from the lowest: compound 4; then compounds 2 and 3 (each within the scatter of the next). At a limit, above all of these: compound 1.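

In this assay, the aromatic carbon meta to a fused ring and para to a fused ring proves sensitive to the group it carries: with bromo in place of trifluoromethyl, the result is a 3.4-fold lower number from compound 2 to compound 4 (0.54 log units; beyond the scatter). Going by these compounds alone, no earlier pair isolated a change at this position, so this is the first reading of its effect with the rest of the structure held constant. The change removes 4 heavy atoms and adds 1 heavy atom, with no hydrogen-bond donors or acceptors on either side, but no measurement shown here gives a reason for the step.

On these data alone, this remains a single exchange at a single position, so it is open whether a nitrile, a methoxy group or plain hydrogen there would fall nearer to bromo or to trifluoromethyl. As far as these compounds go, it is also open whether the step carries over to a longer chain, as compound 1 carries a longer chain and chloro, differs from compound 4 in more than one place, and so allows no reading of either change alone.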